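Permeability notes on the shared-core series, compounds 1 to 4

The source may hold more compounds than are shown below. What is called first, only, known or untested is meant among the compounds shown, and "the series" means these compounds.

Compound 1, `COc1ccc(F)cc1CNCCCNc1ccnc2cc(CCc3ccccc3)ccc12`, in an ADME assay for permeability, using PAMPA, with a stated time of 30 min, at pH 7.4; a higher number here means that the compound crosses the layer faster, a lower number that the compound crosses the layer more slowly: 23 10^-6 cm/s
Compound 2, `COc1ccc(F)cc1CNCCCNc1ccnc2cc(Cc3ccc(C#N)cc3)ccc12`, in this assay: 23 10^-6 cm/s
Compound 3, `COc1ccc(F)cc1CNCCCNc1ccnc2cc(Cc3ccccc3)ccc12`, in this assay: 23 10^-6 cm/s

Compound 3 stands level with the other two: no change at the digits printed from compound 1 to compound 3 (within the scatter) and no change at the digits printed from compound 2 to compound 3 (within the scatter), as does no change at the digits printed from compound 1 to compound 2 (within the scatter). Compound 4, `COc1ccc(F)cc1CNCCCNc1ccnc2cc(Oc3ccccc3OC)ccc12`, is not yet measured. It differs from compound 3 in one place: 2-methoxyphenoxy in place of benzyl on an aromatic carbon. For the measured compounds named here, no measured step swaps the benzyl for a group with hydrogen-bond acceptors, so the bearing steps are only the three above, all within the scatter; varying the group at this position has so far left this assay unmoved. A step within the scatter is therefore expected, a 1.2-fold lower number from compound 3 to compound 4 (0.06 log units; within the scatter). Compound 4 is expected to give 20 10^-6 cm/s, with a range from 10 10^-6 cm/s to 35 10^-6 cm/s.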

Compound 4, apparent permeability: 317 10^-6 cm/s
For compound 4 the middle estimate is 16-fold (1.20 log units) below the measured one, and the stated range ends below it.
By their numbers in this assay, from the lowest: compounds 1, 2 and 3 (each within the scatter of the next); then compound 4.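

In this assay the group at this position can matter after all, with 2-methoxyphenoxy giving large steps (a 14-fold higher number from compound 3 to compound 4 (1.14 log units; beyond the scatter); a 14-fold higher number from compound 2 to compound 4 (1.14 log units; beyond the scatter); a 14-fold higher number from compound 1 to compound 4 (1.14 log units; beyond the scatter)). The level numbers of benzyl, 4-cyanobenzyl and phenethyl therefore describe those three groups and not the position as a whole. Nothing available here bears on what lies behind the step.

The change brings in the ring oxygen link and the methoxy together, and the compounds shown do not separate the two. An unsubstituted phenoxy or a 2-methoxybenzyl group would divide them.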